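From Nitro to Chloro on a Shared Core

The source may hold more compounds than are shown below. What is called first, only, known or untested is meant among the compounds shown, and "the series" means these compounds.

Compound 2 `O=C1NC(=O)/C(=C/c2ccc(OCCSc3nnc(-c4ccc([N+](=O)[O-])cc4)[nH]3)cc2)S1` gives the lowest of the two numbers measured in a functional assay on the whole organism (strain Wistar) with Rattus norvegicus as the target, with a stated time of 15 days, at a dose of 30 mg/kg by the oral route (on this read-out higher numbers stand for a stronger effect at the one dose given and lower numbers for a weaker effect), at 18.6%. For the measured compounds named here, compound 1 `Cc1ccc(-c2nnc(SCCOc3ccc(/C=C4\SC(=O)NC4=O)cc3)[nH]2)cc1` gives 40.3%, and the single measured step, a number 21.7 percentage points lower from compound 1 to compound 2 (beyond the scatter), is the only one that bears on the change ahead, though it swaps a different group. Compound 3 `O=C1NC(=O)/C(=C/c2ccc(OCCSc3nnc(-c4ccc(Cl)cc4)[nH]3)cc2)S1` differs from compound 2 by chloro in place of nitro on an aromatic carbon. Going by the values given here, with no direct precedent for chloro here, a partial return toward the middle is expected, so compound 3 is estimated at 30%, between 15% and 45%. This implies an expected step of a number 11.4 percentage points higher from compound 2 to compound 3 (beyond the scatter), upward but uncertain.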

Compound 3, a percentage reported as activity, at one dose (the size of the read-out at that dose, not a potency): 32.9%
For compound 3 the middle estimate is 2.9 percentage points below the measured one; the measured number falls inside the stated range.
By their numbers in this assay, from the lowest: compound 2; then compounds 3 and 1 (each within the scatter of the next).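

Swapping nitro for chloro at this position gives a number 14.3 percentage points higher from compound 2 to compound 3 (beyond the scatter) in this assay. Chloro in place of methyl gives a number 7.4 percentage points lower from compound 1 to compound 3 (within the scatter), so methyl and chloro cannot be told apart here, while nitro sits clearly lower than both. Nothing available explains why this position responds this way. On these data alone, it remains open whether an amine, a methoxy group or a carboxylic acid on the same aromatic carbon would read like nitro or like methyl and chloro. For the compounds shown here, with only three compounds, these comparisons also cannot show whether the same order would hold for a longer chain on the shared core.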